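This account rests on a few compounds, and the source may have more. Where it says the series, first, only, none or still open, it means among the compounds named here.

Series notes. Compound 1 `CCCCOc1noc2c1CNCC2` gives 7.6 in a physicochemical assay for acid dissociation, and stands level with compound 2 `C#CCOc1noc2c1CNCC2` at 7.6 and with compound 3 `CCCOc1noc2c1CNCC2` at 7.6. Compound 4 `C=CCOc1noc2c1CNCC2` has not been measured. The change from compound 1 to compound 4 is vinyl in place of propyl on a saturated chain carbon bound to an oxygen on an aromatic ring. Going by the values given here, three measured steps bear on this. Ethynyl in place of propyl on the saturated chain carbon bound to the oxygen on the aromatic ring gave no change at the digits printed from compound 1 to compound 2 (within the scatter); ethyl in place of ethynyl at the same place gave no change at the digits printed from compound 2 to compound 3 (within the scatter); hydrogen in place of methyl on a saturated chain carbon three bonds along the chain from that oxygen gave no change at the digits printed from compound 1 to compound 3 (within the scatter). Each change to the chain on the oxygen among these three compounds left this assay unmoved, and vinyl in place of propyl is a change of the same kind at the same place. No step beyond the scatter is therefore expected in this assay. From compound 1 to compound 4 the expected step is no change at the digits printed from compound 1 to compound 4 (within the scatter). Compound 4 is estimated at 7.6, with a range from 7.3 to 7.9.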

Compound 4, acid dissociation constant: 7.5
For compound 4 the middle estimate is 0.10 log units above the measured one; the range from low to high includes it.
By their numbers in this assay, from the lowest: compounds 4, 1, 2 and 3 (each within the scatter of the next).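

In this assay the read-out stays within the scatter when a double bond outside aromatic rings enters on the saturated chain carbon bound to the oxygen on the aromatic ring: a number 0.10 log units lower from compound 1 to compound 4 (within the scatter) with vinyl in place of propyl, a number 0.10 log units lower from compound 3 to compound 4 (within the scatter) with vinyl in place of ethyl, and a number 0.10 log units lower from compound 2 to compound 4 (within the scatter) with vinyl in place of ethynyl. With vinyl added, the ethyl, propyl, ethynyl and vinyl groups at this place all stand within the scatter of one another, and none of the four compounds goes against that. No measurement is available that bears on why the number holds here.

From the compounds shown here alone, whether the same holds for an amine, a carboxylic acid or a longer chain at this place remains open. Changes to the shared core itself also remain open, so the pattern reaches only these four compounds.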